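Removing the Fluorine from the Benzyl Group

The compounds below may be only part of what the source reports. "The series", "measured", "known", "first", "only" and "open" are said of these compounds alone.

Compound 3 `C#CCN(CCCCOc1ccc2ccc(=O)oc2c1)Cc1cccc(F)c1` is one of three compounds tested in an ADME assay on isolated protein for inhibition of Amine oxidase [flavin-containing] A (Homo sapiens), read by fluorescence and Amplex Red, with stated times of 15 min and 20 min (a lower number here means a stronger inhibitor, a higher number a weaker inhibitor), where compound 3 gives 69200 nM. That number is the second highest of the three. Compound 1 `C#CCN(CCCOc1ccc2ccc(=O)oc2c1)Cc1ccc(OC)cc1` gives 60000 nM in this assay, and compound 2 `C#CCN(CCCOc1ccc2ccc(=O)oc2c1)Cc1ccc(C)cc1` gives 116000 nM; compound 3 lies between them, and both gaps are within the scatter, so the three cannot be put in any firm order.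

Compound 4 `C#CCN(CCCCOc1ccc2ccc(=O)oc2c1)Cc1ccccc1` differs from compound 3 in one place: hydrogen in place of fluoro on an aromatic carbon Read one bond further out, 3-fluorobenzyl becomes benzyl. Going by the values given here, only one measured step alters a group on this ring, the change from methoxy to methyl, a 1.9-fold higher number from compound 1 to compound 2 (0.29 log units; within the scatter), which stayed within the scatter. Among the compounds with values here, no measured pair removes a fluoro, so that step bears on the question only indirectly; it shows that a small change on this ring moved the number little. Compound 4 is therefore expected to show a 1.0-fold higher number from compound 3 to compound 4 (0.00 log units; within the scatter), a step no larger than the scatter. The estimated value for compound 4 in this assay is 70000 nM, with a range from 30000 nM to 160000 nM.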

Compound 4, half-maximal inhibitory concentration: 89400 nM
Compound 4: the middle estimate sits 1.3-fold (0.11 log units) below what was measured; low and high end bracket the measured number.
By their numbers in this assay, from the lowest: compounds 1, 3, 4 and 2 (each within the scatter of the next).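

In this assay, going by these compounds alone, the removal of the fluoro gives a 1.3-fold higher number from compound 3 to compound 4 (0.11 log units; within the scatter) and so provides the first measured step that leaves this six-membered aromatic ring without a substituent, whereas the earlier step only exchanged one ring substituent for another. Within this pair, then, the fluoro on the 3-fluorobenzyl group is not needed to keep the number where it stands in compound 3, and the plain benzyl group in compound 4 serves as a reference for judging other groups at this place. No measurement offered here explains why the change leaves the number within the scatter.

The compounds shown leave open whether a larger or differently built group at this place, such as a chloro, a nitrile, a carboxylic acid or a primary amine, would move the number beyond the scatter. They also leave open whether a fluoro elsewhere on the ring, or the same removal of fluoro on a compound with a longer chain, would behave as it does in this pair.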